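The source may hold more compounds than are shown below. What is called first, only, known or untested is meant among the compounds shown, and "the series" means these compounds.

Series values in a physicochemical assay for solubility, at pH 6.5; a higher number here means a more soluble compound, a lower number a less soluble compound:

- compound 1 `Cn1ncc2c(NC3(c4ccc(C(F)(F)F)cc4)CC3)nc(O)nc21` gives 175000 nM
- compound 2 `Cn1ncc2c(NCc3ccc(Cl)cc3)nc(Cl)nc21` gives 145000 nM
- compound 3 `Cn1ncc2c(N3CCCCC3c3ccc(C(F)(F)F)cc3)nc(Cl)nc21` gives 138000 nM

Compound 1 stands level with the other two measured compounds: its value lies within the scatter of both compound 2 and compound 3. The three values therefore set no order within the series.

Compound 4 `Cn1ncc2c(NC3(c4ccc(C(F)(F)F)cc4)CC3)nc(C3CC3)nc21` is still to be measured in this assay. It keeps the core and the amine substituent of compound 1, with cyclopropyl in place of hydroxy on an aromatic carbon, between two ring nitrogen atoms (cyclopropyl in place of hydroxy on an aromatic carbon).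

For the measured compounds named here, no pair of measured compounds differs in one place, so the data give no direct guide to the size of this step, and the expectation is a judgement on the structural change alone. A move to a lower number, beyond the scatter, is expected, with the estimated step being a 3.5-fold lower number from compound 1 to compound 4 (0.54 log units; beyond the scatter). The range is kept wide for that reason.

For compound 4 the estimated value is 50000 nM, with an expected range of 10000 nM to 150000 nM.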

Compound 4, solubility: 125000 nM
Compound 4: the middle estimate sits 2.5-fold (0.40 log units) below what was measured, within the range that was stated.
By their numbers in this assay, from the lowest: compounds 4, 3, 2 and 1 (each within the scatter of the next).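

For the compounds shown here, compound 1 and compound 4 form the first pair that differs in one place. With cyclopropyl in place of hydroxy on an aromatic carbon, between two ring nitrogen atoms, this assay gives a 1.4-fold lower number from compound 1 to compound 4 (0.15 log units; within the scatter). In this one pair, hydroxy, with its hydrogen-bond donor and acceptor, and cyclopropyl, with neither, therefore stand level at this position, and no separate measurement bears on this result.

Going by these compounds, it remains open whether an amine or a carboxylic acid on this aromatic carbon would also stand level with compound 1. A single pair also leaves open whether the same exchange would stay within the scatter with the amine substituents of compound 2 and compound 3.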